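Trimming the Piperidine Acyl Group in a Chemokine Receptor Series

The source may report more compounds than this note shows. Statements on the series, on what has been measured and on what is new or still open speak of the compounds shown alone.

Compound 1 `O=C(Nc1ccc(S(=O)(=O)N2CCCCC2)c2ccccc12)c1ccccc1`: > 30000 nM
Compound 2 `O=C(Nc1ccc(S(=O)(=O)N2CCOCC2)c2ccccc12)c1ccccc1`: 7750 nM
Compound 3 `Cc1ccccc1C(=O)Nc1ccc(S(=O)(=O)NC2CCN(C(=O)C3CCCC3)CC2)c2ccccc12`: 9.1 nM

Three compounds were tested in an assay on L1.2 cells for binding affinity to C-C chemokine receptor type 8 (Homo sapiens); a lower number here means a stronger inhibitor, a higher number a weaker inhibitor. For compound 1 the value is a limit of the assay, not a number (the limit of > 30000 nM in this assay, at which 1 of the 3 values shown sits). Compound 2 gives a number, and the change from compound 1 to compound 2 was morpholin-4-yl in place of piperidin-1-yl on a sulfonyl sulfur, giving an at least 3.8-fold lower number from compound 1 to compound 2 (0.58 log units; beyond the scatter). Compound 3 stands lowest of the two numbers, and the nearest to it is compound 2, far higher.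

Compound 4 `Cc1ccccc1C(=O)Nc1ccc(S(=O)(=O)NC2CCN(C(N)=O)CC2)c2ccccc12` has not yet been measured. It differs from compound 3 in one place: amino in place of cyclopentyl on a carbonyl carbon, cyclopentylcarbonyl to carbamoyl. Among the compounds with values here, the only measured step sits on the sulfonyl sulfur, not on this carbonyl carbon, so it bears little on the change. Removing a five-membered carbon ring and leaving a bare amino group is expected to give a higher number in this assay, a step of a 6.6-fold higher number from compound 3 to compound 4 (0.82 log units; beyond the scatter), within a wide range. Compound 4 is therefore estimated at 60 nM, between 12 nM and 300 nM.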

Compound 4, inhibition constant: 243 nM
For compound 4 the middle estimate is 4.1-fold (0.61 log units) below the measured one, and the stated range covers the measured number.
By their numbers in this assay, from the lowest: compound 3; then compound 4; then compound 2. At a limit, above all of these: compound 1.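

Within the data shown here, the earlier compounds showed change only on a sulfonyl sulfur, so this is the first measured view of the carbonyl carbon, where amino in place of cyclopentyl gives a 27-fold higher number from compound 3 to compound 4 (1.43 log units; beyond the scatter), a large step. The group on this carbonyl carbon therefore matters strongly in this assay, although with the ring gone compound 4 still gives a measured number of 243 nM rather than a limit. Nothing measured here accounts for the size of this step.

As far as these compounds go, whether the step follows from losing the ring carbons or from gaining the amino group stays open, as one replacement cannot separate the two. A methyl group, a longer alkyl chain or a cyclohexyl ring on the same carbonyl carbon would bear on that question.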